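Chain extension in a series without measurable cytotoxicity

This account rests on a few compounds, and the source may have more. Where it says the series, first, only, none or still open, it means among the compounds named here.

Of the compounds shown here, three have been measured in an ADME assay on HeLa cells (Homo sapiens) for cytotoxicity, read by microscopy, with a stated time of 6 days; a lower number here means that less compound is tolerated, a higher number that more compound is tolerated.
Compound 1 `CCCCCCNc1cnc(C(=O)NCc2ccccc2)cn1` gives > 100000 nM, a limit of the assay.
Compound 2 `CCCCNc1nccnc1C(=O)NCc1ccccc1` gives > 100000 nM, a limit of the assay.
Compound 3 `CCCCNc1cncc(C(=O)NCc2ccccc2)n1` gives > 100000 nM, a limit of the assay.

Compound 2 stands where every measured compound stands, at the limit of > 100000 nM in this assay, at which 3 of the 3 values shown sit. No number sets it apart from compound 1 or compound 3, since all three sit at the same limit. Compound 4 `CCCCCCNc1nccnc1C(=O)NCc1ccccc1` has not yet been measured in this assay. It differs from compound 2 by ethyl in place of hydrogen on a saturated chain carbon, four bonds along the chain from a nitrogen on an aromatic ring. Among the measured compounds shown here, no measured pair of compounds isolates this change, so no measured step can be pointed to. Compound 2 shows only a limit. The step in this assay is therefore expected to be a step that the limit leaves unreadable from compound 2 to compound 4, none beyond the scatter. Compound 4 is expected to give 150000 nM, within a range from 50000 nM to 400000 nM, most likely again reported as a limit.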

Compound 4, minimum cytotoxic concentration: > 100000 nM
Compound 4 ended at the assay's limit; the forecaster's own chance of this, stated with the estimate: 85%; the middle value lies beyond the limit too.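

Compound 2 and compound 4 both end at a limit of the assay, so no step between them can be read: the limit of > 100000 nM in this assay, at which 4 of the 4 values shown sit.

The compounds shown leave open at what concentration, if any, any of them becomes cytotoxic.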